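Trifluoromethyl replacing nitro on a sulfonamide at the limit

A few compounds are considered here, and "the series" means these few. Any claim that something is new, unique, unknown or untested is made for them only; others in the source may bear on it.

Compound 2 `CCOC(=O)c1oc2ccc(N(Cc3ccccc3)S(=O)(=O)c3ccc([N+](=O)[O-])cc3)cc2c1C` carries a nitro group on the sulfonyl-bearing ring of the shared core. In a functional assay on HCT-116 cells (Homo sapiens) for inhibition, read by MTT assay, with a stated time of 72 h (on this read-out higher numbers stand for weaker inhibition and lower numbers for stronger inhibition), compound 2 gives > 40000 nM, which is a limit of the assay rather than a measured number. Among the measured compounds shown here, its only measured neighbour, compound 1 `CCOC(=O)c1oc2ccc(N(Cc3ccccc3)S(=O)(=O)c3ccc(OC)cc3)cc2c1C`, differs solely in carrying a methoxy group at that spot. In this assay compound 1 gives > 40000 nM, again a limit. The step that the two limits leave unreadable from compound 1 to compound 2 therefore has no readable size, since (the limit of > 40000 nM in this assay, at which 2 of the 2 values shown sit). Compound 3 `CCOC(=O)c1oc2ccc(N(Cc3ccccc3)S(=O)(=O)c3ccc(C(F)(F)F)cc3)cc2c1C` is the unmeasured analogue; the change from compound 2 is trifluoromethyl in place of nitro on an aromatic carbon. For the measured compounds named here, no measured step shows whether this exchange shifts the read-out in this assay. With both measured compounds sitting at the limit, compound 3 is expected to stay at or close to that limit, and the estimated step that the limit leaves unreadable from compound 2 to compound 3 is taken as none beyond the scatter. The estimate for compound 3 in this assay is 50000 nM, with a range from 15000 nM to 200000 nM.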

Compound 3, half-maximal inhibitory concentration: 26700 nM
Compound 3: middle estimate off by 1.9-fold (0.27 log units), on the high side, within the range that was stated.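

Of the three groups tried at this position, only trifluoromethyl gives a number rather than a limit: in this assay compound 3 gives 26700 nM. The comparison with nitro is an at least 1.4-fold lower number from compound 2 to compound 3 (0.17 log units; that floor lies within the scatter), and the comparison with methoxy is an at least 1.4-fold lower number from compound 1 to compound 3 (0.17 log units; that floor lies within the scatter). These two steps are floors, so the real gaps may be larger, but the part that can be read does not go beyond the scatter, and the result therefore gives only a first hint that this position can affect the read-out: the limit of > 40000 nM in this assay, at which 2 of the 3 values shown sit.

As far as these compounds go, it remains open how the read-out would respond to a group of a different kind at this position, such as an amine or a carboxylic acid. Also open, from the compounds shown here alone, is how far the number could move with a change elsewhere on the shared core.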